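This account rests on a few compounds, and the source may have more. Where it says the series, first, only, none or still open, it means among the compounds named here.

Compound 3 `O=C(O)CCc1ccc(NCc2cccc(F)c2)cc1` gives the highest of the three numbers measured in a functional assay for agonist activity at Free fatty acid receptor 1 (Homo sapiens) (a lower number here means that less compound is needed, a higher number that more compound is needed for the effect), with compound 3 at 5010 nM. Compound 2 `O=C(O)CCc1ccc(NCc2ccccc2Cl)cc1` gives 3980 nM in this assay, a number within the scatter of that of compound 3. Among the compounds with values here, compound 1 `O=C(O)CCc1ccc(NCc2cccc(Br)c2)cc1` gives 794 nM in this assay, and the step of a 6.3-fold higher number from compound 1 to compound 3 (0.80 log units; beyond the scatter) is the only measured change at that position. Compound 4 `O=C(O)CCc1ccc(NCc2ccccc2)cc1` differs from compound 3 by hydrogen in place of fluoro on an aromatic carbon. Within the data shown here, no measured step removes a halogen entirely, so that single bromo-to-fluoro step is the only guide; it shows that what sits at this position matters. Compound 4 is expected to give a number close to that of compound 3, with the estimated step of a 1.1-fold higher number from compound 3 to compound 4 (0.04 log units; within the scatter). The expected value for compound 4 in this assay is 5500 nM, with a range from 2000 nM to 15000 nM.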

Compound 4, half-maximal effective concentration: 7940 nM
Estimate against measurement, compound 4: 1.4-fold (0.16 log units) below; low and high end bracket the measured number.
By their numbers in this assay, from the lowest: compound 1; then compounds 2, 3 and 4 (each within the scatter of the next).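

With hydrogen in place of a halogen, compound 4 gives a baseline for comparing the halogens. In this assay the steps of a 1.6-fold higher number from compound 3 to compound 4 (0.20 log units; within the scatter) and a 2.0-fold higher number from compound 2 to compound 4 (0.30 log units; within the scatter) stay within the scatter, so neither fluoro nor chloro can be told apart from hydrogen, while a 10-fold higher number from compound 1 to compound 4 (1.00 log units; beyond the scatter) lies beyond it, so only bromo stands clearly apart from hydrogen in these compounds. No supporting data explain why bromo stands apart. On these data alone, whether iodo, methyl or methoxy at this place would also give a lower number than hydrogen remains open.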